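A few compounds are considered here, and "the series" means these few. Any claim that something is new, unique, unknown or untested is made for them only; others in the source may bear on it.

Measured in a functional assay on HCT-116 cells (Homo sapiens) for antiproliferative activity, read by sulforhodamine B assay, with a stated time of 72 h; a lower number here means a stronger inhibitor, a higher number a weaker inhibitor:
- compound 1 `COc1ncc(-c2ccc3ncc(NCc4ccccc4)c(OC)c3c2)cc1NS(=O)(=O)c1ccc(F)cc1F`: 16800 nM
- compound 2 `CCNc1cnc2ccc(-c3cnc(OC)c(NS(=O)(=O)c4ccc(F)cc4F)c3)cc2c1OC`: 1850 nM
- compound 3 `COc1ncc(-c2ccc3ncc(NC(=O)CN4CCN(C)CC4)c(OC)c3c2)cc1NS(=O)(=O)c1ccc(F)cc1F`: 1540 nM

The steps into compound 3 place it level with one neighbour, a 1.2-fold lower number from compound 2 to compound 3 (0.08 log units; within the scatter), and clearly ahead of the other, an 11-fold lower number from compound 1 to compound 3 (1.04 log units; beyond the scatter).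

Compound 4 `COc1ncc(-c2ccc3ncc(NC(=O)CN4CCCC(O)C4)c(OC)c3c2)cc1NS(=O)(=O)c1ccc(F)cc1F` puts 3-hydroxypiperidin-1-yl in place of 4-methylpiperazin-1-yl on a saturated chain carbon bound to a carbonyl carbon.

For the measured compounds named here, no measured step alters this ring, so none gives the size directly. Replacing ethyl with the entire side chain made little difference, a 1.2-fold lower number from compound 2 to compound 3 (0.08 log units; within the scatter), while the larger measured steps concern the benzyl group, a 9.1-fold lower number from compound 1 to compound 2 (0.96 log units; beyond the scatter). A swap inside the side chain is therefore expected to stay within the scatter, with no clear direction.

The expected step is a 1.2-fold higher number from compound 3 to compound 4 (0.09 log units; within the scatter).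

For compound 4 the estimated value is 1900 nM, with an expected range of 700 nM to 5500 nM.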

Compound 4, half-maximal inhibitory concentration: 1770 nM
Beside the measured number, compound 4's estimate is 1.1-fold (0.03 log units) above it, and the stated range covers the measured number.
By their numbers in this assay, from the lowest: compounds 3, 4 and 2 (each within the scatter of the next); then compound 1.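

Swapping 4-methylpiperazin-1-yl for 3-hydroxypiperidin-1-yl on this saturated chain carbon bound to a carbonyl carbon changes the ring's hetero atoms and adds a hydrogen-bond donor, yet the number stays level (a 1.1-fold higher number from compound 3 to compound 4 (0.06 log units; within the scatter)). The new side chain also stays level with ethyl (a 1.0-fold lower number from compound 2 to compound 4 (0.02 log units; within the scatter)) and remains clearly ahead of benzyl (a 9.5-fold lower number from compound 1 to compound 4 (0.98 log units; beyond the scatter)). No measured evidence here explains why this ring swap leaves the number in place.

On these data alone, whether a morpholine ring or an open-chain dimethylamino group on the same carbon would also stay level remains open. So does the effect of a carboxylic acid there.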